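The compounds below may be only part of what the source reports. "The series", "measured", "known", "first", "only" and "open" are said of these compounds alone.

All values come from an ADME assay on Vero cells (Chlorocebus sabaeus) for cytotoxicity, read by MTT assay; a higher number here means that more compound is tolerated, a lower number that less compound is tolerated:

- Compound 1 `COc1ccc(-c2nc3cnccn3c2Nc2cc(OC)c(OC)c(OC)c2)cc1O`: 50000 nM
- Compound 2 `COc1cc(Nc2c(-c3cccc(O)c3)nc3cnccn23)cc(OC)c1OC`: 63000 nM
- Compound 3 `COc1cc(Nc2c(-c3ccc(Cl)cc3)nc3cnccn23)cc(OC)c1OC`: 32000 nM

Compound 3 stands within the scatter of both other compounds, with a 1.6-fold lower number from compound 1 to compound 3 (0.19 log units; within the scatter) and a 2.0-fold lower number from compound 2 to compound 3 (0.29 log units; within the scatter). Compound 4 `COc1cc(-c2nc3cnccn3c2Nc2cc(OC)c(OC)c(OC)c2)cc(OC)c1O` has 4-hydroxy-3,5-dimethoxyphenyl in place of 4-chlorophenyl on an aromatic carbon. The two steps to compound 3 are the closest evidence, as each one brings in 4-chlorophenyl in place of a hydroxylated phenyl. Removing a methoxy group also made little difference, with a 1.3-fold higher number from compound 1 to compound 2 (0.10 log units; within the scatter). Compound 4 therefore seems more likely to resemble compound 1 and compound 2, with no change expected beyond the scatter. The expected step is a 1.6-fold higher number from compound 3 to compound 4 (0.19 log units; within the scatter). For compound 4, the estimated value is 50000 nM, with an expected range from 22000 nM to 110000 nM.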

Compound 4, concentration lethal to 50% of the cells: 62000 nM
Estimate against measurement, compound 4: 1.2-fold (0.09 log units) below; low and high end bracket the measured number.
By their numbers in this assay, from the lowest: compounds 3, 1, 4 and 2 (each within the scatter of the next).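

The 4-hydroxy-3,5-dimethoxyphenyl group has more heavy atoms than 4-chlorophenyl, yet this assay shows a 1.9-fold higher number from compound 3 to compound 4 (0.29 log units; within the scatter) at this position. Against the two other hydroxylated phenyl groups, the picture is the same, with a 1.0-fold lower number from compound 2 to compound 4 (0.01 log units; within the scatter) and a 1.2-fold higher number from compound 1 to compound 4 (0.09 log units; within the scatter) on the same shared core. All four groups on this aromatic carbon therefore stay within the scatter of one another, and no measurement here offers an explanation.

All four compounds carry a phenyl ring at this position, so an amine, a carboxylic acid or a longer chain there remains an open case.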